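Notes on a five-membered ring at the aryl position

The source may hold more compounds than are shown below. What is called first, only, known or untested is meant among the compounds shown, and "the series" means these compounds.

Compound 3 `CCC(C)(C)Cc1c[nH]c(CCc2ccc(-c3cccc(N)n3)cc2)n1` gives 37 nM in a functional assay on HEK293 cells for agonist activity at Bombesin receptor subtype-3 (Homo sapiens), read by luminescence and calcium flux, with a stated time of 10 min (on this read-out lower numbers stand for an effect already at smaller amounts and higher numbers for an effect only at larger amounts of compound), and stands lowest of the three measured numbers. Compound 1 `CCC(C)(C)Cc1c[nH]c(CCc2ccc(-c3cccc(C)n3)cc2)n1` gives 105 nM in this assay, and compound 2 `CCC(C)(C)Cc1c[nH]c(CCc2ccc(-n3cccn3)cc2)n1` gives 135 nM. The step of a 2.8-fold lower number from compound 1 to compound 3 (0.45 log units; beyond the scatter) and the step of a 3.6-fold lower number from compound 2 to compound 3 (0.56 log units; beyond the scatter) both run downward beyond the scatter, whereas a 1.3-fold higher number from compound 1 to compound 2 (0.11 log units; within the scatter) stays within it.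

Compound 4 `CCC(C)(C)Cc1c[nH]c(CCc2ccc(-c3csnn3)cc2)n1` is to be measured in this assay. Its difference from compound 3 is 1,2,3-thiadiazol-4-yl in place of 6-aminopyridin-2-yl on an aromatic carbon. The change removes the 6-aminopyridin-2-yl group that enters in both steps beyond the scatter; the group that arrives, like the 1H-pyrazol-1-yl of compound 2, is a five-membered aromatic ring. For the measured compounds named here, no measured step carries the 1,2,3-thiadiazol-4-yl itself, so the nearest guides are a 2.8-fold lower number from compound 1 to compound 3 (0.45 log units; beyond the scatter) and a 3.6-fold lower number from compound 2 to compound 3 (0.56 log units; beyond the scatter) read in reverse, each a modest rise on leaving the amino-bearing ring. An upward step of similar size is therefore expected for compound 4, as a 3.2-fold higher number from compound 3 to compound 4 (0.51 log units; beyond the scatter). In this assay compound 4 is estimated at 120 nM, with a range from 45 nM to 320 nM.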

Compound 4, half-maximal effective concentration: 538 nM
Compound 4: the middle estimate sits 4.5-fold (0.65 log units) below what was measured, and the stated range ends below it.
By their numbers in this assay, from the lowest: compound 3; then compounds 1 and 2 (each within the scatter of the next); then compound 4.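

Working notes on the aryl position: a five-membered aromatic ring here does not by itself fix the read-out in this assay, since a 4.0-fold higher number from compound 2 to compound 4 (0.60 log units; beyond the scatter) separates 1,2,3-thiadiazol-4-yl from 1H-pyrazol-1-yl, two groups that the earlier compounds could only have suggested were alike. For the compounds shown here, the same group also stands apart from the six-membered aromatic rings, with a 5.1-fold higher number from compound 1 to compound 4 (0.71 log units; beyond the scatter) against 6-methylpyridin-2-yl and a 15-fold higher number from compound 3 to compound 4 (1.16 log units; beyond the scatter) against 6-aminopyridin-2-yl, the latter the only large step at this place on an aromatic carbon para to a large group and well beyond the modest steps among the first three compounds. No measurement at hand accounts for the size of these steps.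

The step from compound 3 to compound 4 changes ring size, hetero atoms and the hydrogen-bond donor together, so the compounds shown cannot say which of these goes with the higher number. Going by these compounds, a thiazol-4-yl or a 1,2,3-triazol-4-yl at this place, and an unsubstituted pyridin-2-yl, would each bear on that question, and whether the sulfur or the amino group matters more remains open.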